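Moving the methyl group: 3-methylphenyl to 4-methylphenyl

A few compounds are considered here, and "the series" means these few. Any claim that something is new, unique, unknown or untested is made for them only; others in the source may bear on it.

Compound 1 `O=c1[nH]c2ccc(Cl)cc2n1S(=O)(=O)Cc1ccccc1Cl`: 52000 nM
Compound 2 `Cc1cccc(CS(=O)(=O)n2c(=O)[nH]c3ccc(Cl)cc32)c1`: 110000 nM

In an ADME assay on MT4 cells (Homo sapiens) for cytotoxicity, read by MTT assay, with a stated time of 5 days (on this read-out lower numbers stand for higher toxicity in this test and higher numbers for lower toxicity in this test), compound 2 stands as the higher of the two measured compounds, at 110000 nM. Compound 3 `Cc1ccc(CS(=O)(=O)n2c(=O)[nH]c3ccc(Cl)cc32)cc1` has yet to be measured. It differs from compound 2 by 4-methylphenyl in place of 3-methylphenyl on a saturated chain carbon bound to a sulfonyl sulfur, with 4-methylphenyl in place of 3-methylphenyl on a saturated chain carbon bound to a sulfonyl sulfur. The two have the same atoms, joined differently. Among the measured compounds shown here, only one measured step bears on this change: a 2.1-fold higher number from compound 1 to compound 2 (0.33 log units; beyond the scatter). That step is modest and exchanges a 2-chlorophenyl for the 3-methylphenyl, so the data do not show what moving the methyl does. No shift beyond the scatter is therefore expected, and the estimated step is a 1.1-fold lower number from compound 2 to compound 3 (0.04 log units; within the scatter). For compound 3 the estimated value is 100000 nM, with an expected range of 45000 nM to 210000 nM.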

Compound 3, half-maximal cytotoxic concentration: 93000 nM
Estimate against measurement, compound 3: 1.1-fold (0.03 log units) above; the measured number falls inside the stated range.
By their numbers in this assay, from the lowest: compounds 1, 3 and 2 (each within the scatter of the next, the first and the last beyond it).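

In this assay, moving the methyl group gives a 1.2-fold lower number from compound 2 to compound 3 (0.07 log units; within the scatter), so on a saturated chain carbon bound to a sulfonyl sulfur, 3-methylphenyl and 4-methylphenyl are not told apart by this read-out. The exchange of 2-chlorophenyl also looks less firm than the first pair suggested: a 2.1-fold higher number from compound 1 to compound 2 (0.33 log units; beyond the scatter), but a 1.8-fold higher number from compound 1 to compound 3 (0.25 log units; within the scatter), so a methylphenyl in place of 2-chlorophenyl does not move the number beyond the scatter in every case. Nothing at hand accounts for these numbers.

The compounds shown leave open whether a carboxylic acid or an amine on the phenyl ring, or a longer chain in place of the saturated chain carbon, would separate from these values. They also leave open how the cytotoxicity read here relates to any other effect of these compounds.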